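A few compounds are considered here, and "the series" means these few. Any claim that something is new, unique, unknown or untested is made for them only; others in the source may bear on it.

In a functional assay on NCI-H1975 cells (Homo sapiens) for inhibition, read by sulforhodamine B assay, tested at 10 uM (on this read-out higher numbers stand for more inhibition at the one concentration tested (going by the name of the read-out) and lower numbers for less inhibition), compound 1 `CN(C)c1ccc(C2CC(c3ccc(-n4cncn4)cc3)=NN2S(C)(=O)=O)cc1` gives -3.1% and compound 2 `COC(=O)CC(=O)N1N=C(c2ccc(-n3ccnc3)cc2)CC1c1ccc(N(C)C)cc1` gives -0.1%. Compound 2 stands highest of these two numbers, but the gap to compound 1 is within the scatter, so the two numbers are level. Compound 3 `CN(C)c1ccc(C2CC(c3ccc(-n4ccnc4)cc3)=NN2S(C)(=O)=O)cc1` differs from compound 2 by one change: methylsulfonyl in place of ((methoxycarbonyl)methyl)carbonyl on an amine nitrogen in a ring. Both measured compounds sit near zero, and the step of a number 0.1 percentage points higher from compound 2 to compound 3 (within the scatter) is expected to stay within the scatter, in no clear direction. Compound 3 is therefore estimated at 0%, with a range from -12% to 12%.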

Compound 3, a percentage reported as inhibition, at one concentration (the size of the read-out at that concentration, not a potency): -3.8%
Compound 3: the middle estimate sits 3.8 percentage points above what was measured, and the stated range covers the measured number.
By their numbers in this assay, from the lowest: compounds 3, 1 and 2 (each within the scatter of the next).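

In this assay, methylsulfonyl in place of ((methoxycarbonyl)methyl)carbonyl on the amine nitrogen in the ring gives a number 3.7 percentage points lower from compound 2 to compound 3 (within the scatter), and 1H-imidazol-1-yl in place of 1H-1,2,4-triazol-1-yl on the aromatic carbon gives a number 0.7 percentage points lower from compound 1 to compound 3 (within the scatter). Neither change separates its pair at this one concentration, so both places show no measurable effect so far. Nothing available explains these near-zero numbers. On these data alone, whether a carboxylic acid or a longer chain on that amine nitrogen, or an amine on that aromatic carbon, would move the number away from zero remains open.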